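The source may report more compounds than this note shows. Statements on the series, on what has been measured and on what is new or still open speak of the compounds shown alone.

Four compounds share one core and differ in the amide hanging from a saturated chain carbon bound to an aromatic nitrogen, and in whether the other end carries an acid or an ethyl ester. Compound 1 `C/C=C/C(=O)Nc1cccc(Cn2nc(-c3ccc(Oc4ccccc4)cc3)cc2C(=O)O)c1` gives 31600 nM in a functional assay on Maver1 cells (Homo sapiens) for inhibition, read by luminescence and CellTiter-Glo, with a stated time of 72 h; on this read-out lower numbers stand for stronger inhibition and higher numbers for weaker inhibition. Compound 2 `C=CC(=O)Nc1ccc(Cn2nc(-c3ccc(Oc4ccccc4)cc3)cc2C(=O)OCC)cc1` gives 13300 nM in this assay. Compound 3 `C/C=C/C(=O)Nc1ccc(Cn2nc(-c3ccc(Oc4ccccc4)cc3)cc2C(=O)OCC)cc1` gives only a limit in this assay, > 60000 nM, so its true number is not known. For the measured compounds named here, the one measured step that reaches compound 3 is an at least 4.5-fold higher number from compound 2 to compound 3 (0.65 log units; beyond the scatter), and it ends at the limit of > 60000 nM in this assay, at which 1 of the 3 values shown sits. Compound 4 `C/C=C/C(=O)Nc1cccc(Cn2nc(-c3ccc(Oc4ccccc4)cc3)cc2C(=O)OCC)c1` differs from compound 3 by 3-(((prop-1-en-1-yl)carbonyl)amino)phenyl in place of 4-(((prop-1-en-1-yl)carbonyl)amino)phenyl on a saturated chain carbon bound to an aromatic nitrogen. Going by the values given here, no measured pair changes only this placement. Compound 1 holds the same amide placement as compound 4 but an acid in place of the ethyl ester, and in this assay compound 1 gives 31600 nM, a number rather than a limit. For compound 4 a modest step downward is therefore expected, an at least 1.5-fold lower number from compound 3 to compound 4 (0.17 log units; that floor lies within the scatter), though with wide uncertainty since compound 3 is only a limit. Compound 4 is estimated to give 40000 nM, with a range from 15000 nM to 100000 nM.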

Compound 4, half-maximal inhibitory concentration: 14200 nM
Estimate against measurement, compound 4: 2.8-fold (0.45 log units) above; measured number outside the range, below it.
By their numbers in this assay, from the lowest: compounds 2 and 4 (each within the scatter of the next); then compound 1. At a limit, above all of these: compound 3.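

The 3-(((prop-1-en-1-yl)carbonyl)amino)phenyl group in place of the 4-(((prop-1-en-1-yl)carbonyl)amino)phenyl group gives an at least 4.2-fold lower number from compound 3 to compound 4 (0.62 log units; beyond the scatter) in this assay, and that size is only a floor: the limit of > 60000 nM in this assay, at which 1 of the 4 values shown sits.

With the amide placement held, ethyl in place of hydrogen on the oxygen next to a carbonyl group gives a 2.2-fold lower number from compound 1 to compound 4 (0.35 log units; beyond the scatter). There is also a 1.1-fold higher number from compound 2 to compound 4 (0.03 log units; within the scatter), but that step changes placement and amide end together, so it cannot be credited to either one alone.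

The compounds shown leave open how a 3-((vinylcarbonyl)amino)phenyl group would compare, which would separate those two changes. They also leave open whether a longer chain than ethyl on the ester, or a primary amide in its place, would change the number.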